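Notes on amide-nitrogen substituents, compounds 1 to 4

A few compounds are considered here, and "the series" means these few. Any claim that something is new, unique, unknown or untested is made for them only; others in the source may bear on it.

Measured in an assay on HEK293 cells for agonist activity at transient receptor potential cation channel subfamily M member 8 (Homo sapiens), read by fluorescence and calcium flux, with a stated time of 15 min; on this read-out higher numbers stand for an effect only at larger amounts of compound and lower numbers for an effect already at smaller amounts:
compound 1 `Cc1ccc(OCC(=O)N(Cc2cccs2)C2COC2)cc1`: 23000 nM
compound 2 `Cc1ccc(OCC(=O)N(Cc2cccs2)c2c[nH]nc2C)cc1`: 0.4 nM
compound 3 `Cc1ccc(OCC(=O)N(Cc2cccs2)C(C)C)cc1`: 70 nM

Compound 3 stands second highest of the three numbers. Its nearest neighbour is compound 2, a 180-fold higher number from compound 2 to compound 3 (2.24 log units; beyond the scatter); its furthest is compound 1, a 330-fold lower number from compound 1 to compound 3 (2.52 log units; beyond the scatter). Both steps are large and beyond the scatter, so the substituent on the amide-type nitrogen has moved the read-out strongly in either direction among the measured compounds.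

Compound 4 `Cc1ccc(OCC(=O)N(O)Cc2cccs2)cc1` is not yet measured. It differs from compound 3 in one place: hydroxy in place of isopropyl on an amide-type nitrogen. Within the data shown here, no measured pair exchanges isopropyl for hydroxy, so no step bears on it directly. The exchanges that do bear on the same position are a 330-fold lower number from compound 1 to compound 3 (2.52 log units; beyond the scatter) and a 180-fold higher number from compound 2 to compound 3 (2.24 log units; beyond the scatter); each is large, so a small or scatter-sized step for compound 4 would be the surprise here. The direction cannot be read from the data. The working expectation is a step toward higher numbers, a 71-fold higher number from compound 3 to compound 4 (1.85 log units; beyond the scatter), guided by compound 1, whose value 23000 nM shows that a small substituent at this nitrogen can sit far above compound 3.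

Estimate for compound 4 in this assay: 5000 nM, within 400 nM to 60000 nM.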

Compound 4, half-maximal effective concentration: 8000 nM
Estimate against measurement, compound 4: 1.6-fold (0.20 log units) below, within the range that was stated.
By their numbers in this assay, from the lowest: compound 2; then compound 3; then compound 4; then compound 1.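

In this assay, hydroxy in place of isopropyl on the amide-type nitrogen gives a 110-fold higher number from compound 3 to compound 4 (2.06 log units; beyond the scatter) and so takes the number well away from the low end of the series, while the gap to the pyrazole is wider still, with a 20000-fold higher number from compound 2 to compound 4 (4.30 log units; beyond the scatter) as the step. The step to the oxetane is far smaller, with a 2.9-fold lower number from compound 1 to compound 4 (0.46 log units; beyond the scatter) as a modest change that remains beyond the scatter, so among these four compounds the two groups that hold oxygen, hydroxy and oxetan-3-yl, give the two highest numbers, and no compound shown goes against that ordering. The data shown offer no measured explanation for this ordering at the nitrogen.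

Open, from the compounds shown here alone, is whether the oxygen itself tracks with the higher numbers or whether this only holds for these two groups, which methoxy or a longer chain ending in hydroxy on the same nitrogen would test against ethyl or tert-butyl. Also open, going by these compounds, is how much of the low number of compound 2 depends on its methyl, a question for 1H-pyrazol-4-yl without that methyl and for other aromatic rings such as phenyl at this nitrogen.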